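The source may report more compounds than this note shows. Statements on the series, on what has been measured and on what is new or still open speak of the compounds shown alone.

In an in vivo ADME assay on the whole organism (strain Sprague-Dawley) for pharmacokinetics, with Rattus norvegicus as the target, at a dose of 1 mg/kg (a lower number here means that a smaller share of the oral dose reaches the circulation, a higher number that a larger share of the oral dose reaches the circulation), compound 1 `CC(C)(O)c1ccn2c(-c3ccc(F)c(-c4cccnc4)c3)cnc2n1` gives 77%. Compound 2 `CC(C)(O)c1cnn2c(-c3ccc(F)c(-c4ncc(F)cc4F)c3)cnc2n1` gives 69%, and these two numbers lie within the usual scatter of each other. Compound 3 `CC(C)(O)c1cnn2c(-c3ccc(F)c(-c4ncccc4C#N)c3)cnc2n1` has 3-cyanopyridin-2-yl in place of the 3,5-difluoropyridin-2-yl of compound 2, on an aromatic carbon (3-cyanopyridin-2-yl in place of 3,5-difluoropyridin-2-yl on an aromatic carbon). Among the compounds with values here, no measured pair shows a comparable single change. No step beyond the scatter is expected in this assay. The estimated step is a number 7 percentage points lower from compound 2 to compound 3 (within the scatter). For compound 3 the expected value is 62%, with an estimated range of 38% to 85%.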

Compound 3, oral bioavailability: 102%
Compound 3: the middle estimate sits 40 percentage points below what was measured; measured number outside the range, above it.
By their numbers in this assay, from the lowest: compounds 2 and 1 (each within the scatter of the next); then compound 3.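

In this assay, the group on this aromatic carbon, ortho to a fluoro group, proves able to move oral bioavailability: 3-cyanopyridin-2-yl in place of 3,5-difluoropyridin-2-yl gives a number 33 percentage points higher from compound 2 to compound 3 (beyond the scatter) on an otherwise unchanged structure. Within the data shown here, this single pair is the first readable step. Nothing available bears on why the step occurs.

The pair cannot separate the effect of adding the nitrile from that of losing the two fluorines. On these data alone, a 3-fluoropyridin-2-yl or 3-carboxamidopyridin-2-yl group at this position remains open, as does whether the step carries over to the core of compound 1.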